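The compounds below may be only part of what the source reports. "The series", "measured", "known", "first", "only" and "open" are said of these compounds alone.

Values measured so far in a functional assay on the whole organism with Mus musculus as the target, in the rotarod test; a lower number here means that less compound is needed, a higher number that more compound is needed for the effect:

- compound 1 `CN(C)C(=O)/C=C1\CCc2c(F)cc(F)cc21` gives 100 mg/kg
- compound 2 `O=C(/C=C1\CCc2c(F)cc(F)cc21)NC1CC1` gives 62 mg/kg
- compound 3 `CC(C)NC(=O)/C=C1\CCc2ccc(F)cc21` gives > 100 mg/kg

Compound 3 stands at > 100 mg/kg, which is a limit and not a number.

Compound 4 `CC(C)NC(=O)/C=C1\CCc2c(F)cc(F)cc21` keeps the amide group of compound 3 and takes fluoro in place of hydrogen on an aromatic carbon. This gives it the core of compound 1 and compound 2.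

Going by the values given here, no measured step covers this change. Among the compounds with values here, the only one measured is a change on the carbonyl carbon, a 1.6-fold lower number from compound 1 to compound 2 (0.21 log units; within the scatter), and it lies within the scatter. It suggests that this assay responds little to that part of the structure, though this rests on a single pair.

The expectation therefore rests on the shared core, with compound 1 at 100 mg/kg and compound 2 at 62 mg/kg. A lower number than the limit of compound 3 is expected, and the expected step is an at least 1.5-fold lower number from compound 3 to compound 4 (0.18 log units; that floor lies within the scatter), which remains uncertain because its starting point is only a limit. For compound 4 the estimate is 65 mg/kg, with an expected range from 30 mg/kg to 130 mg/kg.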

Compound 4, dose for half-maximal effect: 76 mg/kg
Beside the measured number, compound 4's estimate is 1.2-fold (0.07 log units) below it, within the range that was stated.
By their numbers in this assay, from the lowest: compounds 2, 4 and 1 (each within the scatter of the next).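

In this assay, fluoro in place of hydrogen on the aromatic carbon ortho to a fused ring now has a first reading, an at least 1.3-fold lower number from compound 3 to compound 4 (0.11 log units; that floor lies within the scatter), so the change is seen only as a floor. This step stays a floor because the value of compound 3 is a limit and not a number: the limit of > 100 mg/kg in this assay, at which 1 of the 4 values shown sits. On the shared core, the isopropylamino, cyclopropylamino and dimethylamino amides do not separate, with a 1.2-fold higher number from compound 2 to compound 4 (0.09 log units; within the scatter) and a 1.3-fold lower number from compound 1 to compound 4 (0.12 log units; within the scatter).

On these data alone, the true size of the fluoro step stays open, including whether it goes beyond the scatter. Also open, as far as these compounds go, is how chloro or methoxy on this aromatic carbon, or a longer chain on the amide nitrogen, would read in this assay.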